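The compounds below may be only part of what the source reports. "The series", "measured", "known", "first", "only" and "open" are said of these compounds alone.

Compound 1, `COC(=O)c1ccc(NCc2cncn2Cc2cccc(C)c2)cc1-c1ccccc1`, was measured in a toxicity assay on NIH3T3 cells (Mus musculus) for cytotoxicity, read by resazurin assay; on this read-out lower numbers stand for an effect already at smaller amounts and higher numbers for an effect only at larger amounts of compound. In this assay compound 1 gives > 10000 nM, a limit of the assay rather than a number.
Compound 2, `COC(=O)c1ccc(NCc2cncn2Cc2ccc(N)cc2)cc1-c1ccccc1`: in this assay compound 2 gives > 10000 nM, again a limit and not a number.
Compound 3, `COC(=O)c1ccc(NCc2cncn2Cc2ccccc2OC)cc1-c1ccccc1`: in this assay compound 3 gives "not determined" (no result reported), so no result is reported for it.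

For the measured compounds named here, the one measured step, a step that the two limits leave unreadable from compound 1 to compound 2, cannot be read in size because the limit of > 10000 nM in this assay, at which 2 of the 3 values shown sit, hides both ends of it. Compound 3 therefore stands nowhere on the numbers shown: its two companions sit at a limit, and it carries no value of its own.

The step to follow leads from compound 3 to compound 4, `COC(=O)c1ccc(NCc2cncn2Cc2ccc(C#N)cc2)cc1-c1ccccc1`. The change is 4-cyanophenyl in place of 2-methoxyphenyl on a saturated chain carbon bound to an aromatic nitrogen. Going by the values given here, no measured step bears on this change, and the one step that exists tells nothing of size. Among the compounds with values here, the only guidance is that both measured companions of compound 3 reach the limit, so compound 4 is expected to do the same, with no step beyond the scatter foreseen in either direction. Compound 4 is estimated at 15000 nM, within 5000 nM to 50000 nM, most likely reported as a limit.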

Compound 4, half-maximal effective concentration: > 10000 nM
Compound 4: only a limit was reported; the forecaster's own chance of this, stated with the estimate: 80%; the middle value lies beyond the limit too.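

No step to compound 4 can be read from compound 1 or compound 2, because all three compounds end at a limit of the assay and not at a number: the limit of > 10000 nM in this assay, at which 3 of the 4 values shown sit.

The compounds shown leave open whether the groups varied on the shared core differ at all in this assay.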